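Swapping an amine chain for a fluorobenzyl group

This account rests on a few compounds, and the source may have more. Where it says the series, first, only, none or still open, it means among the compounds named here.

Three compounds share one core, and two of them carry a number in a functional assay on HCT-116 cells (Homo sapiens) for cytotoxicity, read by MTT assay, with a stated time of 72 h; a lower number here means a stronger inhibitor, a higher number a weaker inhibitor. Compound 1 `C[C@@H](CO)Nc1nc(C(=O)NCc2ccc(F)cc2)c(O)c2ncccc12` gives "not determined" (no result reported) in this assay. Compound 2 `CNCCCNc1c(C(=O)NCc2ccc(F)cc2)nc(Br)c2cccnc12` gives 9000 nM in this assay, the highest of the two numbers available. Compound 3 `COc1ccc(CNC(=O)c2nc(Br)c3cccnc3c2N[C@H]2CC[C@H](N)CC2)cc1` gives 3000 nM in this assay, a value that sits beyond the usual scatter from that of compound 2, so compound 3 is the stronger inhibitor of the two.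

Compound 4 `O=C(NCc1ccc(F)cc1)c1nc(Br)c2cccnc2c1NCc1ccc(F)cc1` has not yet been measured. It differs from compound 2 in a single place: 4-fluorophenyl in place of 2-(methylamino)ethyl on a saturated chain carbon bound to a nitrogen on an aromatic ring. For the measured compounds named here, no pair of measured compounds shows this particular change, so there is no measured step to lean on; compound 3 differs from compound 2 in more than one place and cannot isolate the effect of the chain.

With nothing directly comparable on hand, the expectation is a step from compound 2 to compound 4 of no change at the digits printed from compound 2 to compound 4 (within the scatter), which is best read as no clear move beyond the scatter in either direction. The estimated value for compound 4 is therefore 9000 nM, with a range from 3000 nM to 27000 nM.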

Compound 4, half-maximal inhibitory concentration: > 20000 nM
Compound 4 gave a limit, no number (the forecaster's own chance of this, stated with the estimate: 20%); at least 2.2-fold (0.34 log units) between middle value and limit.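

In this assay compound 4 gives > 20000 nM, which is a limit of the assay and not a number. Even so, the change has a readable direction, with an at least 2.2-fold higher number from compound 2 to compound 4 (0.34 log units; beyond the scatter), so 4-fluorophenyl in place of 2-(methylamino)ethyl on a saturated chain carbon bound to a nitrogen on an aromatic ring makes for a weaker compound here. This is the first measured single change at this place, which compounds 2 and 3 could not provide, yet only its direction and minimum size are known, and the result rests on one value that is not a number: the limit of > 20000 nM in this assay, at which 1 of the 4 values shown sits.

The step removes a chain holding an amine and brings in an aromatic ring carrying fluorine, so the compounds shown cannot tell whether losing the amine, gaining the ring, or both goes with the weaker result. A plain butyl chain with no nitrogen at this place would help separate the loss of the amine from the gain of the ring, and an unsubstituted benzyl group would show whether the fluorine matters.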